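The source may report more compounds than this note shows. Statements on the series, on what has been measured and on what is new or still open speak of the compounds shown alone.

The series shares a common core, seen in compound 1, `CS(=O)(=O)Nc1ccc(C(C(=O)NCc2ccc(C(F)(F)F)nc2SC2CCCCC2)C2CCCCC2)cc1F`, which in an assay on CHO cells for antagonist activity at transient receptor potential cation channel subfamily V member 1 (Homo sapiens), read by FLIPR (on this read-out lower numbers stand for stronger inhibition and higher numbers for weaker inhibition), is recorded as "active" (no number reported), without a number. Among the measured compounds shown here, compound 2, `Cc1ccc(C(C(=O)NCc2ccc(C(F)(F)F)nc2SC2CCCCC2)c2ccc(NS(C)(=O)=O)c(F)c2)cc1`, carries a 4-methylphenyl on the saturated chain carbon bound to an aromatic carbon and a carbonyl carbon, and in this assay compound 2 gives 7.5 nM, the only numerical value available here, so it stands as the single point of reference. Compound 3, `CS(=O)(=O)Nc1ccc(C(Cc2ccccc2)C(=O)NCc2ccc(C(F)(F)F)nc2SC2CCCCC2)cc1F`, is built from the same atoms joined differently: benzyl in place of 4-methylphenyl on a saturated chain carbon bound to an aromatic carbon and a carbonyl carbon. For the measured compounds named here, no pair of measured compounds with a single difference is available, so the size of this kind of change cannot be read from any measured step. Because compound 2 reaches 7.5 nM with the aryl group directly on that carbon, the expectation for compound 3 is a modest weakening, of a size near the edge of the usual scatter, expressed by the step of a 2.7-fold higher number from compound 2 to compound 3 (0.43 log units; beyond the scatter). Compound 3 is therefore expected to give about 20 nM in this assay, most likely between 5 nM and 80 nM.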

Compound 3, inhibition constant: "active" (no number reported)
The entry for compound 3 holds no number, and the estimate cannot be compared.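

In this assay, among the compounds shown here, compound 3 is recorded as active without a number, so no step from compound 2 can be read. Nothing shown here offers evidence that bears on this result. The compounds shown leave open how far benzyl in place of 4-methylphenyl on a saturated chain carbon shifts the inhibition constant.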